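The source may report more compounds than this note shows. Statements on the series, on what has been measured and on what is new or still open speak of the compounds shown alone.

Compound 1 `CCCCCc1ccc(S(=O)(=O)c2c(C)cc(C)cc2C)cc1` gives > 300000 nM in an assay on isolated protein for antagonist activity at Rap guanine nucleotide exchange factor 4 (Homo sapiens), read by fluorescence and cAMP accumulation; on this read-out lower numbers stand for stronger inhibition and higher numbers for weaker inhibition; this is a limit of the assay, not a number.
Compound 2 `COc1ccc(S(=O)(=O)c2c(C)cc(C)cc2C)cc1` gives 1900 nM in this assay.
Compound 3 `Cc1cc(C)c(S(=O)(=O)c2ccc(OC3CCNCC3)cc2)c(C)c1` gives > 300000 nM in this assay; this too is a limit of the assay, not a number.

Compound 3 therefore stands at the weak end of what has been measured, sharing its position with compound 1, as the limit of > 300000 nM in this assay, at which 2 of the 3 values shown sit, shows. Only compound 2 carries a real number. The step of an at least 150-fold higher number from compound 2 to compound 3 (2.19 log units; beyond the scatter) shows that placing piperidin-4-yl in place of methyl on the oxygen turned that number into a limit, while an at least 150-fold lower number from compound 1 to compound 2 (2.19 log units; beyond the scatter) shows how much the methoxy group gained over pentyl. The step that the two limits leave unreadable from compound 1 to compound 3 runs between two limits and says nothing about size.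

Compound 4 `Cc1cc(C)c(S(=O)(=O)c2ccc(OCCN)cc2)c(C)c1` differs from compound 3 in one place: 2-aminoethyl in place of piperidin-4-yl on an oxygen on an aromatic ring. The basic amine stays, but the ring is gone and the chain is shorter. Among the measured compounds shown here, the step of an at least 150-fold higher number from compound 2 to compound 3 (2.19 log units; beyond the scatter) is the one that bears on this change, since it is the only measured step at the same oxygen, and it was large in the weakening direction. For the measured compounds named here, no measured compound with an amine on that oxygen has given a number, so compound 4 is expected to stay weak, with the step of an at least 2.0-fold lower number from compound 3 to compound 4 (0.30 log units; that floor lies within the scatter) as the estimated outcome. Compound 4 is estimated at 150000 nM, between 15000 nM and 1500000 nM.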

Compound 4, half-maximal inhibitory concentration: > 300000 nM
Compound 4: no number, only a limit; the forecaster's own chance of this, stated with the estimate: 55%; at least 2.0-fold (0.30 log units) between middle value and limit.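

Compound 4 also returns only a limit of the assay, so replacing the piperidin-4-yl ring with the open 2-aminoethyl chain, which has fewer heavy atoms and no ring, did not restore a measurable number at this oxygen. With aminomethyl in place of a hydrogen on the saturated chain carbon bound to the oxygen, the methoxy group of compound 2 becomes the 2-aminoethoxy group, and the result is an at least 150-fold higher number from compound 2 to compound 4 (2.19 log units; beyond the scatter), so a small addition at this carbon is enough to lose the number. The steps from compound 1 and from compound 3 to compound 4 run between two limits and cannot be read, and the series now stands like this: the limit of > 300000 nM in this assay, at which 3 of the 4 values shown sit.

Going by these compounds, what remains open is whether the loss at this oxygen follows from the amine itself or from any group larger than methyl, a question that a plain ethyl or a 2-hydroxyethyl on the same oxygen would address. Compound 1, which carries pentyl and no amine, also gives only a limit, so an amine is not needed for a compound in this set to end at the limit.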